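Bicyclic aryl swapped for ethoxypyridyl on the chain

A few compounds are considered here, and "the series" means these few. Any claim that something is new, unique, unknown or untested is made for them only; others in the source may bear on it.

Measured so far in an assay on isolated protein for binding affinity to somatostatin receptor type 1 (Homo sapiens); a lower number here means tighter binding, a higher number weaker binding:
compound 1 `COC(=O)c1cc(CC(C)CN2C[C@H]3CCCC[C@H]3[C@@H](C(=O)N3CCN(c4ccc([N+](=O)[O-])cc4)CC3)C2)cc(C(=O)OC)c1` gives 2340 nM
compound 2 `Cc1nc2cc(C[C@H](C)CN3C[C@@H]4CCCC[C@@H]4[C@H](C(=O)N4CCN(c5ccc(F)c(F)c5)CC4)C3)ccc2o1` gives 1380 nM
compound 3 `Cc1cn2cc(C[C@H](C)CN3C[C@@H]4CCCC[C@@H]4[C@H](C(=O)N4CCN(c5ccc(F)c(F)c5)CC4)C3)ccc2n1` gives 39.8 nM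

Compound 3 holds the lowest number of the three in this assay. The nearest measured compound is compound 2, reached through the step of a 35-fold lower number from compound 2 to compound 3 (1.54 log units; beyond the scatter); compound 1 lies furthest away, its value and that of compound 3 standing well apart, beyond the scatter.

Compound 4 `CCOc1ccc(C[C@H](C)CN2C[C@@H]3CCCC[C@@H]3[C@H](C(=O)N3CCN(c4ccc(F)c(F)c4)CC3)C2)cn1` differs from compound 3 by a group of 9 heavy atoms (7 carbon, 1 nitrogen, 1 oxygen; one six-membered aromatic ring with 1 hetero atom) in place of a group of 10 heavy atoms (8 carbon, 2 nitrogen; one five-membered aromatic ring with 2 hetero atoms, one six-membered aromatic ring with 1 hetero atom), on a saturated chain carbon, three bonds along the chain from an amine nitrogen in a ring. Within the data shown here, only one measured step bears on this place: the step of a 35-fold lower number from compound 2 to compound 3 (1.54 log units; beyond the scatter), which exchanged one fused aromatic group for another of the same atom count on the same chain carbon and moved the number by a large amount. Among the measured compounds shown here, that step shows the aryl group at this place matters strongly, but it does not cover the loss of the five-membered ring, and no measured compound carries a single six-membered aromatic ring here. The expected step for compound 4 is therefore uncertain in size; on the whole a shift toward a higher number than compound 3 is expected, a 7.5-fold higher number from compound 3 to compound 4 (0.88 log units; beyond the scatter). For compound 4 the estimate in this assay is 300 nM, with a range from 50 nM to 1800 nM.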

Compound 4, dissociation constant: 2340 nM
Compound 4: the middle estimate sits 7.8-fold (0.89 log units) below what was measured; measured number outside the range, above it.
By their numbers in this assay, from the lowest: compound 3; then compounds 2, 1 and 4 (each within the scatter of the next).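

In this assay, replacing the fused group of compound 3 with 6-ethoxypyridin-3-yl on this saturated chain carbon gives a 59-fold higher number from compound 3 to compound 4 (1.77 log units; beyond the scatter), so the low number of compound 3 does not carry over to a group with a single six-membered aromatic ring. The other step, a 1.7-fold higher number from compound 2 to compound 4 (0.23 log units; within the scatter), leaves 6-ethoxypyridin-3-yl and 2-methyl-1,3-benzoxazol-5-yl indistinguishable in this assay, so a fused aromatic group at this place does not by itself give a low number, and compound 3 is the only one of the three sharing this core and differing here that stands apart. Nothing available explains the differences among these three groups.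

The compounds shown leave open whether the ethoxy group or the single-ring aryl itself accounts for the number of compound 4, which a methoxy in place of the ethoxy, or the same pyridine ring carrying no ethoxy, would help separate. Also open, from the compounds shown here alone, is how much of the low number of compound 3 depends on the methyl on its five-membered ring, as against the two ring nitrogens of its fused group.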